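This account rests on a few compounds, and the source may have more. Where it says the series, first, only, none or still open, it means among the compounds named here.

Two compounds anchor the series in an ADME assay on Caco-2 cells (Homo sapiens) for permeability, in the apical to basolateral direction; a higher number here means that the compound crosses the layer faster, a lower number that the compound crosses the layer more slowly. Compound 1 `CC(C)(C)CC[C@H]1C[C@@H](c2cc(=O)[nH]o2)CCN1` gives 4.5 10^-6 cm/s, the higher of the two numbers, and compound 2 `CN1CCC(c2cc(=O)[nH]o2)CC1` gives 1 10^-6 cm/s. The gap between them lies beyond the usual scatter. Within the data shown here, these two differ in more than one place, so no measured single-change step is available, and the gap cannot be assigned to any one feature.

The next compound is compound 3 `CC(C)C[C@H]1C[C@@H](c2cc(=O)[nH]o2)CCN1`, which departs from compound 1 by one change: isopropyl in place of neopentyl on a saturated chain carbon bound to a saturated ring carbon. Among the measured compounds shown here, with no measured step to calibrate against, a small drop in this assay is expected, probably not beyond the scatter. Compound 3 shares more of its structure with compound 1, at 4.5 10^-6 cm/s, than with compound 2, so the expectation stays nearer the upper number. The expected size of the change is a 1.4-fold lower number from compound 1 to compound 3 (0.15 log units; within the scatter). For compound 3 the estimated value is 3.2 10^-6 cm/s, with an expected range of 1.4 10^-6 cm/s to 6.5 10^-6 cm/s.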

Compound 3, apparent permeability: 1 10^-6 cm/s
Compound 3: the middle estimate sits 3.2-fold (0.51 log units) above what was measured; measured number below the stated range.
By their numbers in this assay, from the lowest: compounds 2 and 3 (each within the scatter of the next); then compound 1.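

Among these compounds, at the saturated chain carbon bound to a saturated ring carbon, isopropyl in place of neopentyl gives a 4.5-fold lower number from compound 1 to compound 3 (0.65 log units; beyond the scatter) in this assay, the first measured single-change step. This position is therefore not silent in this read-out: with the rest of the core of compound 1 unchanged, a change in this side chain alone moves the number beyond the scatter, which the gap between the two anchoring compounds could not show. No measurement available here bears on the reason for this step.

A single pair cannot separate the number of chain carbons from the branching, since 3,3-dimethylbutyl and isobutyl, as the same difference reads one bond further out, differ in both. An unbranched n-butyl or n-pentyl chain at this place would help to separate the two, while a chain ending in a hydroxyl or an amine would show whether the step holds beyond all-carbon side chains.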